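The compounds below may be only part of what the source reports. "The series", "measured", "known", "first", "only" and "open" are said of these compounds alone.

Compound 1 `CN1/C(=C/C=C/C2=[N+](CCCc3ccccc3)c3ccccc3C2(C)C)C(C)(C)c2ccccc21` gives 35% in an assay for displacement of a labelled ligand from protein arginine N-methyltransferase 1 (Homo sapiens), read by scintillation proximity assay, with stated times of 5 min and 8 min, tested at 10 uM (on this read-out higher numbers stand for a stronger effect at the one concentration tested and lower numbers for a weaker effect), the higher of the two numbers recorded so far. Compound 2 `CCCCN1/C(=C/C=C/C2=[N+](CCCC)c3ccc(Cl)cc3C2(C)C)C(C)(C)c2cc(Cl)ccc21` gives 34% in this assay, a number within the scatter of compound 1, so the two are not distinguished. Compound 3 `CN1/C(=C/C=C/C2=[N+](CCC[N+](C)(C)C)c3ccccc3C2(C)C)C(C)(C)c2ccccc21` differs from compound 1 by a group of 4 heavy atoms (3 carbon, 1 nitrogen; no ring) in place of a group of 6 heavy atoms (6 carbon; one six-membered aromatic ring of carbon only), on a saturated chain carbon, three bonds along the chain from a double-bonded nitrogen in a ring. For the measured compounds named here, no measured pair covers a change of this kind, so there is nothing to set its size against. The step of a number 5 percentage points lower from compound 1 to compound 3 (within the scatter) is expected to stay within the scatter, with no direction claimed. Compound 3 is estimated at 30%, between 10% and 50%.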

Compound 3, a percentage reported as inhibition, at one concentration (the size of the read-out at that concentration, not a potency): 2%
Compound 3: middle estimate off by 28 percentage points, on the high side; the measured number lies below the stated range.
By their numbers in this assay, from the lowest: compound 3; then compounds 2 and 1 (each within the scatter of the next).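

In this assay, this position on the saturated chain carbon is the first shown to be sensitive to substitution: replacing phenyl with the group of net charge +1 gives a number 33 percentage points lower from compound 1 to compound 3 (beyond the scatter). The change removes the ring and adds the charge at once, so the step cannot be assigned to either alone. Nothing available explains the loss.

As far as these compounds go, it remains open whether cyclohexyl at this place would retain the read-out of compound 1. A dimethylamino group or a longer chain ending in phenyl would also test how far this position tolerates change.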